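A second chloro on compound 3

A few compounds are considered here, and "the series" means these few. Any claim that something is new, unique, unknown or untested is made for them only; others in the source may bear on it.

Going by the values given here, in an ADME assay on BJ cells (Homo sapiens) for cytotoxicity, with a stated time of 72 h (on this read-out higher numbers stand for an effect only at larger amounts of compound and lower numbers for an effect already at smaller amounts), no compound measured so far gives a number. Compound 1 `Cc1ccc(NC(=O)Nc2cc(C)nc3ccccc23)cc1` reaches only a limit, > 25000 nM. Compound 2 `Cc1cc(NC(=O)Nc2ccc(SC(F)(F)F)cc2)c2ccccc2n1` also reaches only a limit, > 25000 nM. Compound 3 `Cc1cc(NC(=O)Nc2ccc(Cl)cc2)c2ccccc2n1` likewise stands at a limit, > 25000 nM. The three therefore share one position: the limit of > 25000 nM in this assay, at which 3 of the 3 values shown sit.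

Compound 4 `Cc1cc(NC(=O)Nc2ccc(Cl)cc2Cl)c2ccccc2n1` differs from compound 3 in one place: chloro in place of hydrogen on an aromatic carbon.

Among the compounds with values here, three measured steps bear on this change: a step that the two limits leave unreadable from compound 1 to compound 3, a step that the two limits leave unreadable from compound 2 to compound 3 and a step that the two limits leave unreadable from compound 1 to compound 2. None has a readable size, and none puts chloro in place of hydrogen. The expectation therefore rests on compound 3, whose reading is the limit > 25000 nM. No step beyond the scatter is expected in this assay, and a reading at the limit is the likeliest outcome. The expected step is a step that the limit leaves unreadable from compound 3 to compound 4. Compound 4 is estimated at 30000 nM, with an expected range from 12000 nM to 60000 nM.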

Compound 4, half-maximal effective concentration: 20000 nM
The estimate for compound 4 lay 1.5-fold (0.18 log units) above the measured number; measured number inside the range.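

In this assay compound 4 is the first compound shown to give a number rather than a limit, and the steps among the earlier compounds cannot be read. Chloro in place of hydrogen, ortho to a large group, gives an at least 1.2-fold lower number from compound 3 to compound 4 (0.09 log units; that floor lies within the scatter), so this change yields only a floor for the step and shows no step beyond the scatter. Compound 4 therefore stands apart from the other compounds only in having a number, while the rest remain at a shared limit: the limit of > 25000 nM in this assay, at which 3 of the 4 values shown sit.

Going by these compounds, the true size of this step remains open. So does whether a fluoro, a methyl or an amine on the same aromatic carbon would also give a number rather than a limit.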